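The source may hold more compounds than are shown below. What is called first, only, known or untested is meant among the compounds shown, and "the series" means these compounds.

Measured so far in a functional assay on PC-3 cells (Homo sapiens) for inhibition, read by sulforhodamine B assay, with a stated time of 48 h, tested at 50 uM; a lower number here means less inhibition of growth, a higher number more inhibition of growth at the concentration tested:

- compound 1 `COc1cc(/C=C/C(=O)/C=C/c2ccco2)ccc1OCc1cn(CCCOc2cc(=O)oc3ccccc23)nn1` gives "not active" (no number reported)
- compound 2 `COc1ccc(/C=C/C(=O)/C=C/c2ccc(OCc3cn(CCCOc4cc(=O)oc5ccccc45)nn3)c(OC)c2)cc1OC` gives 9%

Within the data shown here, compound 2 holds the only number, so there is no second number to rank it against. Compound 1 was reported without one.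

Next is compound 3 `COc1ccc(/C=C/C(=O)/C=C/c2ccc(OCc3cn(CCCOc4cc(=O)oc5ccccc45)nn3)c(OC)c2)cc1`, which is compound 2 with a single change: hydrogen in place of methoxy on an aromatic carbon. This puts hydrogen in place of methoxy on an aromatic carbon, ortho to a methoxy group and meta to a large group, so that 3,4-dimethoxyphenyl becomes 4-methoxyphenyl.

Among the measured compounds shown here, no two measured compounds differ in one place only, so the series offers no measured step to scale this change against. With compound 2 at 9% as the sole anchor, no shift beyond the usual scatter is expected in this assay, and neither direction is favoured. The expected change is a number 1 percentage points lower from compound 2 to compound 3 (within the scatter), which stays within that scatter. A report without a number, as for compound 1, also remains possible.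

For compound 3 the estimate is 8%, with an expected range from 0% to 20%.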

Compound 3, percent growth inhibition at one concentration: "not active" (no number reported)
Nothing numeric was reported for compound 3; the estimate stays without a comparison.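

In this assay, among these compounds, compound 3 is reported as "not active" (no number reported) and compound 2 gives 9% with a number on its side only, so no step between them can be read. No supporting data bear on this result. The compounds shown leave open whether changing 3,4-dimethoxyphenyl to 4-methoxyphenyl shifts growth inhibition at all.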